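A few compounds are considered here, and "the series" means these few. Any claim that something is new, unique, unknown or untested is made for them only; others in the source may bear on it.

Compound 1 `COc1ccc(-c2ccc3c(NCCCNCc4cccc(OC)c4O)ccnc3c2)cc1` gives 1600 nM in an ADME assay on HepG2 cells (Homo sapiens) for cytotoxicity, read by luminescence, CellTiter-Glo and ATP content, with a stated time of 72 h; on this read-out higher numbers stand for an effect only at larger amounts of compound and lower numbers for an effect already at smaller amounts.
Compound 2 `COc1ccc(-c2ccc3c(NCCCNCc4ccco4)ccnc3c2)cc1` gives 6000 nM in this assay.
Compound 3 `COc1ccc(-c2ccc3c(NCCCNCc4cc(F)ccc4OC)ccnc3c2)cc1` gives 5960 nM in this assay.

Among these three numbers compound 3 stands second highest. Its nearest neighbour is compound 2: the step of a 1.0-fold lower number from compound 2 to compound 3 (0.00 log units; within the scatter) lies within the scatter, so the two compounds cannot be told apart on this read-out. Its furthest neighbour is compound 1, reached by the step of a 3.7-fold higher number from compound 1 to compound 3 (0.57 log units; beyond the scatter), which goes beyond the scatter. The step of a 3.8-fold higher number from compound 1 to compound 2 (0.57 log units; beyond the scatter) is of the same size. All three measured steps change the group on a saturated chain carbon bound to an amine nitrogen, while the 4-methoxyphenyl group stayed the same in every measured compound.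

Compound 4 `COc1ccc(F)cc1CNCCCNc1ccnc2cc(-c3ccc(C(F)(F)F)cc3)ccc12` differs from compound 3 by trifluoromethyl in place of methoxy on an aromatic carbon. Among the compounds with values here, no measured step touches this position, so the measured steps give no direction for the change; the expectation is therefore a step of a 1.0-fold higher number from compound 3 to compound 4 (0.00 log units; within the scatter) that stays within the scatter. On that basis compound 4 is expected to give about 6000 nM in this assay, within a range from 2500 nM to 14000 nM.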

Compound 4, half-maximal effective concentration: 5190 nM
For compound 4 the middle estimate is 1.2-fold (0.06 log units) above the measured one, and the stated range covers the measured number.
By their numbers in this assay, from the lowest: compound 1; then compounds 4, 3 and 2 (each within the scatter of the next).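

Within the data shown here, this is the first measured change on the 4-methoxyphenyl group, and in this assay the step of a 1.1-fold lower number from compound 3 to compound 4 (0.06 log units; within the scatter) leaves the two compounds indistinguishable. On this one pair, the read-out therefore does not respond to replacing methoxy, which counts one hydrogen-bond acceptor, with the larger trifluoromethyl, which counts none. Nothing available accounts for this result.

From the compounds shown here alone, what remains open is whether this position stays just as unresponsive with quite different groups there, such as an amine or a carboxylic acid. Going by these compounds, it is also open whether the same exchange would leave the number unchanged with the 2-hydroxy-3-methoxyphenyl group of compound 1 on the chain, since that group goes with the lowest number so far.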